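The compounds below may be only part of what the source reports. "The series", "measured", "known", "first", "only" and "open" are said of these compounds alone.

Measured compounds:
compound 1, `CC(=O)Nc1cccc(C2CCN(CCCn3c(-c4ccccc4Cl)nc4ccccc43)CC2)c1`, gives 10 nM in an assay for displacement of a labelled ligand from melanin-concentrating hormone receptor 1 (Homo sapiens), read by fluorescence; a lower number here means a stronger inhibitor, a higher number a weaker inhibitor
compound 2, `CCc1ccc(-c2nc3ccccc3n2CCCN2CCC(c3cccc(NC(C)=O)c3)CC2)cc1`, gives 32 nM in this assay

Among these two values compound 2 holds the higher number; its nearest neighbour is compound 1, and the step of a 3.2-fold higher number from compound 1 to compound 2 (0.51 log units; beyond the scatter) lies beyond the scatter. Compound 3, `CC(=O)Nc1cccc(C2CCN(CCCn3c(-c4ccc(Cl)cc4Cl)nc4ccccc43)CC2)c1`, differs from compound 2 in one place: 2,4-dichlorophenyl in place of 4-ethylphenyl on an aromatic carbon. Among the compounds with values here, the only measured step that bears on this change is a 3.2-fold higher number from compound 1 to compound 2 (0.51 log units; beyond the scatter), which followed the reverse direction at the same position, a 2-chlorophenyl giving way to the 4-ethylphenyl. Within the data shown here, compound 3 brings a chlorine back to that ring while also carrying a second chlorine, for which no measured pair gives guidance. Compound 3 is therefore expected to move back toward the value of compound 1, with the expected step of a 2.7-fold lower number from compound 2 to compound 3 (0.43 log units; beyond the scatter) in this assay being modest and downward. The estimate for compound 3 is 12 nM, within a range from 4 nM to 40 nM.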

Compound 3, half-maximal inhibitory concentration: 3 nM
Compound 3: the middle estimate sits 4.0-fold (0.60 log units) above what was measured; measured number outside the range, below it.
By their numbers in this assay, from the lowest: compound 3; then compound 1; then compound 2.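

On the aromatic carbon between two ring nitrogen atoms, 2,4-dichlorophenyl in place of 4-ethylphenyl gives an 11-fold lower number from compound 2 to compound 3 (1.03 log units; beyond the scatter) in this assay and so makes the largest step seen at this position. Chloro in place of hydrogen on the 2-chlorophenyl ring gives a 3.3-fold lower number from compound 1 to compound 3 (0.52 log units; beyond the scatter) and shows what the earlier pair could not: the ring of compound 1 can take a further chlorine with a lower number, and compound 3 has the lowest number of the three. Nothing available explains this gain.

The compounds shown leave open whether a 4-chlorophenyl alone would match the 2,4-dichlorophenyl. They also leave open whether a bromo or methoxy group in place of the added chlorine would give a similar number.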